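Methoxy for bromo on the indoline-fused diterpenoid ester

The source may hold more compounds than are shown below. What is called first, only, known or untested is meant among the compounds shown, and "the series" means these compounds.

Of the compounds shown here, two have been measured in a functional assay on A549 cells (Homo sapiens) for inhibition, read by sulforhodamine B assay, with a stated time of 48 h; on this read-out lower numbers stand for stronger inhibition of growth and higher numbers for weaker inhibition of growth. Compound 1 `COC(=O)[C@@]1(C)CCC=C2[C@@H]1CC[C@@H](C)[C@]2(C)Cc1c(C)[nH]c2c(Cl)cccc12` gives 20000 nM in this assay. Compound 2 `COC(=O)[C@@]1(C)CC[C@@H]2C3=C1CC[C@@H](C)[C@]3(C)C[C@@H]1c3cc(Br)ccc3N[C@H]21` gives 40000 nM in this assay. Of the two numbers, that of compound 2 stands at the top, but the distance to compound 1 is within the usual scatter of repeated measurements, so the two readings cannot be told apart on this evidence.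

The step under consideration leads from compound 2 to compound 3 `COC(=O)[C@@]1(C)CC[C@@H]2C3=C1CC[C@@H](C)[C@]3(C)C[C@@H]1c3cc(OC)ccc3N[C@H]21`, which is not yet measured in this assay. The change is methoxy in place of bromo on an aromatic carbon. For the measured compounds named here, no pair of measured compounds differing in one place is available, so no measured step can be used as a guide, and the two numbers on hand give no indication that a change at this position moves the read-out beyond the scatter.

Compound 3 is therefore expected to sit close to compound 2, with the step of no change at the digits printed from compound 2 to compound 3 (within the scatter) estimated to be none beyond the scatter. Compound 3 is estimated at 40000 nM in this assay, within a range from 15000 nM to 100000 nM.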

Compound 3, concentration for 50% growth inhibition: 22000 nM
For compound 3 the middle estimate is 1.8-fold (0.26 log units) above the measured one; the range from low to high includes it.
By their numbers in this assay, from the lowest: compounds 1, 3 and 2 (each within the scatter of the next).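

The exchange of bromo for methoxy gives the first step measured at this aromatic carbon, which stands meta to a fused ring and para to a fused ring: in this assay the read-out shows a 1.8-fold lower number from compound 2 to compound 3 (0.26 log units; within the scatter). The position therefore accepts a group with one more heavy atom and a hydrogen-bond acceptor, in place of a single bromine, without a change that can be told from the scatter, something the two earlier numbers could not show because compound 1 and compound 2 differ in more than one place. Nothing on hand bears on what lies behind this reading.

What the compounds shown leave open is whether an amine or a carboxylic acid on this aromatic carbon, or a chain longer than methoxy, would carry the read-out beyond the scatter in either direction. With only bromo and methoxy to compare here, they also leave open whether this position has any real influence on growth inhibition in this assay, since a single step within the scatter cannot settle that.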